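The source may hold more compounds than are shown below. What is called first, only, known or untested is meant among the compounds shown, and "the series" means these compounds.

Three compounds of the series have been run in a functional assay on T47D cells (Homo sapiens) for cytotoxicity, read by CCK-8 assay; a higher number here means a weaker inhibitor, a lower number a stronger inhibitor. Compound 1 `Oc1cccc(-c2cc(-c3ccsc3)cc(-c3ccccc3O)n2)c1` returns only a limit, > 50000 nM. Compound 2 `Oc1cccc(-c2cc(-c3ccsc3)cc(-c3cccc(O)c3)n2)c1` gives 1510 nM, and compound 3 `Oc1cccc(-c2cc(-c3ccccn3)cc(-c3ccccc3O)n2)c1` gives 2560 nM; compound 2 and compound 3 sit within the usual scatter of each other. From the compounds shown here alone, the change 3-hydroxyphenyl in place of 2-hydroxyphenyl on an aromatic carbon brought an at least 33-fold lower number from compound 1 to compound 2 (1.51 log units; beyond the scatter), a step whose full size stays open because of the limit of > 50000 nM in this assay, at which 1 of the 3 values shown sits. Compound 3 differs from compound 1 in its core by pyridin-2-yl in place of thiophen-3-yl on an aromatic carbon, and that change brought an at least 19-fold lower number from compound 1 to compound 3 (1.29 log units; beyond the scatter).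

Compound 4 `Oc1cccc(-c2cc(-c3ccccn3)cc(-c3cccc(O)c3)n2)c1` is not yet measured. It differs from compound 3 by 3-hydroxyphenyl in place of 2-hydroxyphenyl on an aromatic carbon, the same kind of change as that made from compound 1 to compound 2; the surroundings differ in that the site here is meta to a pyridin-2-yl group (6 heavy atoms) rather than meta to a thiophen-3-yl group (5 heavy atoms). How the two cores differ has already been given.

For compound 4 a step of a 10-fold lower number from compound 3 to compound 4 (1.01 log units; beyond the scatter) is expected, smaller than the earlier one, resting on compound 3 starting from a measured value, 2560 nM. Compound 4 is accordingly expected to give about 250 nM, between 40 nM and 1500 nM.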

Compound 4, half-maximal inhibitory concentration: 1410 nM
Beside the measured number, compound 4's estimate is 5.6-fold (0.75 log units) below it, within the range that was stated.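

In this assay, 3-hydroxyphenyl in place of 2-hydroxyphenyl gives a 1.8-fold lower number from compound 3 to compound 4 (0.26 log units; within the scatter), so this change does not carry over at the size seen on the core of compound 1: the same change on two cores in this assay, an at least 33-fold lower number (1.51 log units; beyond the scatter) from compound 1 to compound 2 and a 1.8-fold lower number (0.26 log units; within the scatter) from compound 3 to compound 4, at least 18-fold (1.26 log units) apart, beyond the scatter of two such steps

Pyridin-2-yl in place of thiophen-3-yl gives a 1.1-fold lower number from compound 2 to compound 4 (0.03 log units; within the scatter), so that change does not carry from one core to the other either: the same change on two cores in this assay, an at least 19-fold lower number (1.29 log units; beyond the scatter) from compound 1 to compound 3 and a 1.1-fold lower number (0.03 log units; within the scatter) from compound 2 to compound 4, at least 18-fold (1.26 log units) apart, beyond the scatter of two such steps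

Both large steps start from compound 1, the only compound that returns a limit, so their full size stays open, and this set of four shows a dependence on the core only here, not a rule for the series or its cause: the limit of > 50000 nM in this assay, at which 1 of the 4 values shown sits.

From the compounds shown here alone, it remains open whether the pairing of thiophen-3-yl with 2-hydroxyphenyl in compound 1 is a lone exception or whether other groups in the place of thiophen-3-yl would behave in the same way. Also open, going by these compounds, is how an amine or a carboxylic acid in place of the hydroxy group on the phenyl ring would read in this assay.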